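Solubility notes on compounds 1 to 4

The compounds below may be only part of what the source reports. "The series", "measured", "known", "first", "only" and "open" are said of these compounds alone.

Measured so far in a physicochemical assay for solubility, read by HPLC, using the shake flask method, measured as kinetic solubility, with a stated time of 2 h, at pH 7.4; on this read-out lower numbers stand for lower solubility and higher numbers for higher solubility:
- compound 1 `Cc1ccc(-c2cnn3c(NCc4ccccn4)cc(C)nc23)cc1` gives a limit, < 5000 nM
- compound 2 `Cc1cc(Nc2ccccn2)n2nc(C)c(-c3ccccc3)c2n1` gives a limit, < 5000 nM
- compound 3 `Cc1cc(NCc2ccco2)n2nc(C)c(-c3ccccc3)c2n1` gives a limit, < 5000 nM

Every value shown is a limit of the assay rather than a number, as the limit of < 5000 nM in this assay, at which 3 of the 3 values shown sit, makes plain. Compound 1 therefore stands only at that limit, with no number to rank it against the others. Within the data shown here, the one measured step, a step that the two limits leave unreadable from compound 2 to compound 3, has both ends at the limit and so has no readable size.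

Compound 4 `Cc1cc(NCc2ccccn2)n2ncc(-c3cccc(N(C)C)c3)c2n1` differs from compound 1 by 3-(dimethylamino)phenyl in place of 4-methylphenyl on an aromatic carbon. Among the measured compounds shown here, no measured step touches a group at this place, so no size for the change can be drawn from the data. For compound 4 the estimated value in this assay is 3000 nM, expected between 500 nM and 9000 nM, and most probably reported again only as a limit. The expected step that the limit leaves unreadable from compound 1 to compound 4 is accordingly not expected to be readable beyond the scatter.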

Compound 4, solubility: 94600 nM
For compound 4 the middle estimate is 32-fold (1.50 log units) below the measured one; the measured number lies above the stated range.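

In this assay, among these compounds, 3-(dimethylamino)phenyl in place of 4-methylphenyl on an aromatic carbon gives an at least 18-fold higher number from compound 1 to compound 4 (1.27 log units; beyond the scatter), the first readable step. This place on the shared core can therefore carry a large change in the read-out. Compound 4 is also the only compound shown with a number rather than a limit: the limit of < 5000 nM in this assay, at which 3 of the 4 values shown sit.

The compounds shown do not separate the effect of swapping methyl for dimethylamino from that of its different place on the phenyl ring. Going by these compounds, how a morpholine or a carboxylic acid on that phenyl ring would read also stays open.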